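Swapping an Aryl Cap for a Thiazole on the Thiazolidinone

A few compounds are considered here, and "the series" means these few. Any claim that something is new, unique, unknown or untested is made for them only; others in the source may bear on it.

The series shares a thiazolidinone core carrying a benzamide arm, and the compounds differ in the group on the ring nitrogen and in the amide tail. Compound 1 `COc1ccc(C)cc1N1C(=O)CSC1c1cccc(C(=O)NCCCCc2ccccc2)c1` gives 300 nM in a functional assay on HOS-TE85 cells (Homo sapiens) for inhibition, read by CCK-8 assay, with a stated time of 72 h (a higher number here means a weaker inhibitor, a lower number a stronger inhibitor), the lowest of the two numbers reported, with compound 2 `CCOC(=O)c1sc(N2C(=O)CSC2c2cccc(C(=O)NCCCCn3cccn3)c2)nc1C` giving 430 nM in this assay, a gap within the scatter. Compound 3 `O=C(NCCCCn1cccn1)c1cccc(C2SCC(=O)N2c2ccncc2)c1` reaches only the limit of > 1000 nM in this assay. Within the data shown here, the one measured step is an at least 2.3-fold higher number from compound 2 to compound 3 (0.36 log units; beyond the scatter), which shows that a six-membered pyridine in that position weakens inhibition relative to a substituted thiazole.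

Compound 4 `O=C(NCCCCc1ccccc1)c1cccc(C2SCC(=O)N2c2nccs2)c1` has not yet been measured. It differs from compound 1 by 1,3-thiazol-2-yl in place of 2-methoxy-5-methylphenyl on an amide-type nitrogen in a ring. The measured step bears on this change only loosely: it shows that a five-membered heteroaryl on the ring nitrogen is tolerated, since compound 2 stays near compound 1, while the pyridine of compound 3 is not. A small to modest weakening is therefore expected, within or just beyond the scatter. Compound 4 is estimated at 500 nM, with a likely range from 200 nM to 1500 nM. That corresponds to an expected 1.7-fold higher number from compound 1 to compound 4 (0.22 log units; within the scatter).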

Compound 4, half-maximal inhibitory concentration: > 1000 nM
Compound 4 ended at the assay's limit (the forecaster's own chance of this, stated with the estimate: 20%); middle value at least 2.0-fold (0.30 log units) from the limit.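

With the shared core and the amide tail held constant, compound 1 and compound 4 isolate the group on the amide-type nitrogen in a ring, and replacing the aryl group with an unsubstituted thiazole carries a clear cost, with an at least 3.3-fold higher number from compound 1 to compound 4 (0.52 log units; beyond the scatter). In this assay compound 4 gives > 1000 nM, which is a limit of the assay and not a number. This is the first step at this position that starts from the 2-methoxy-5-methylphenyl group, and alongside an at least 2.3-fold higher number from compound 2 to compound 3 (0.36 log units; beyond the scatter) it gives a second change there that lies beyond the scatter, although neither step has a fixed size and the two cannot be ranked against each other: the limit of > 1000 nM in this assay, at which 2 of the 4 values shown sit.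

The compounds shown leave open how far compound 4 lies past the limit, and whether a plain phenyl on this nitrogen would keep the activity of compound 1 or whether its methoxy and methyl groups are needed. They also leave open whether a methyl group or a carboxylic acid on the 1,3-thiazol-2-yl ring would recover activity with the amide tail of compound 4.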